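A few compounds are considered here, and "the series" means these few. Any claim that something is new, unique, unknown or untested is made for them only; others in the source may bear on it.

Working notes on the series in a functional assay; on this read-out higher numbers stand for weaker inhibition and lower numbers for stronger inhibition: compound 1 `CC(C)=CCOc1ccc2c(c1)OC(c1cccc(F)c1)CC2=O` gives 4280 nM, compound 2 `CC(C)=CCOc1ccc2c(c1)OC(c1ccc(F)cc1)CC2=O` gives 7320 nM and compound 3 `CC(C)=CCOc1ccc2c(c1)OC(c1ccc(Cl)cc1Cl)CC2=O` gives 5260 nM, so compound 3 stands within the scatter of both others. The next compound is compound 4 `CC(C)=CCOc1ccc2c(c1)OC(c1cccc(Br)c1)CC2=O`, with 3-bromophenyl in place of 2,4-dichlorophenyl on a saturated ring carbon, next to the ring oxygen. Three measured changes at this carbon bear on it: a 1.7-fold higher number from compound 1 to compound 2 (0.23 log units; within the scatter), a 1.2-fold higher number from compound 1 to compound 3 (0.09 log units; within the scatter) and a 1.4-fold lower number from compound 2 to compound 3 (0.14 log units; within the scatter). Going by the values given here, all stay within the scatter, though no 3-bromophenyl compound has a measured value yet. No step beyond the scatter is therefore expected in this assay. The expected step is a 1.1-fold lower number from compound 3 to compound 4 (0.04 log units; within the scatter). Compound 4 is estimated at 4800 nM, with an expected range of 2400 nM to 9500 nM.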

Compound 4, half-maximal inhibitory concentration: 5280 nM
Estimate against measurement, compound 4: 1.1-fold (0.04 log units) below, within the range that was stated.
By their numbers in this assay, from the lowest: compounds 1, 3, 4 and 2 (each within the scatter of the next).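

In this assay the 3-bromophenyl group on the saturated ring carbon gives a 1.0-fold higher number from compound 3 to compound 4 (0.00 log units; within the scatter) and a 1.4-fold lower number from compound 2 to compound 4 (0.14 log units; within the scatter) and also a 1.2-fold higher number from compound 1 to compound 4 (0.09 log units; within the scatter) and all three steps stay within the scatter. Bromo therefore joins fluoro and chloro on this phenyl ring without separating any of the four compounds. Nothing available explains why these groups read alike.

As far as these compounds go, all four compounds carry a halogenated phenyl group at this carbon, so the response to other groups remains open. An unsubstituted phenyl, or a phenyl bearing an amine or a carboxylic acid, would test whether this position responds at all.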